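Syringaldehyde-type hydrazones: trimming one methoxy from compound 1

The compounds below may be only part of what the source reports. "The series", "measured", "known", "first", "only" and "open" are said of these compounds alone.

Measured so far:
compound 1 `COc1cc(/C=N/N(C)c2nc3ccccc3s2)cc(OC)c1O` — 5%
compound 2 `COc1cc(/C=N/N(C)c2nc3ccccc3s2)cc(OC)c1OC` — 84%

In a physicochemical assay on cells (Homo sapiens), with a stated time of 18 h, tested at 1 uM (on this read-out lower numbers stand for a stronger effect and higher numbers for a weaker effect at the one concentration tested), compound 1 gives 5%, the lowest of the two numbers in hand; its nearest neighbour is compound 2, which gives 84%. Within the data shown here, the one measured step, a number 79 percentage points higher from compound 1 to compound 2 (beyond the scatter), is large and beyond the scatter, and it turns only on the hydroxy group being capped.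

Compound 3 `COc1cc(/C=N/N(C)c2nc3ccccc3s2)ccc1O` is not yet measured. It differs from compound 1 by hydrogen in place of methoxy on an aromatic carbon. Among the measured compounds shown here, the hydroxy group itself is kept, so the measured step does not bear directly on this change; no step in hand tests the loss of a methoxy group. With the hydroxy group retained, the expectation is that compound 3 stays nearer compound 1 than compound 2, with a moderate step upward, a number 15 percentage points higher from compound 1 to compound 3 (beyond the scatter), estimated at 20% (range 3% to 60%).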

Compound 3, a percentage reported as activity, at one concentration (the size of the read-out at that concentration, not a potency): 20%
Estimate against measurement, compound 3: no gap at the digits printed; low and high end bracket the measured number.
By their numbers in this assay, from the lowest: compound 1; then compound 3; then compound 2.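

In this assay, among these compounds, the step of a number 15 percentage points higher from compound 1 to compound 3 (beyond the scatter) gives the first reading on the methoxy position ortho to the hydroxy group: the position responds to the change, but the step is modest. The earlier step, a number 79 percentage points higher from compound 1 to compound 2 (beyond the scatter), concerned the hydroxy group and is the larger of the two, and with the hydroxy group kept, compound 3 retains a low number at 20%, so a strong effect in this small set does not depend on having both methoxy groups. No measurement in hand accounts for the size of either step.

As far as these compounds go, it remains open how this aromatic carbon responds to groups other than hydrogen and methoxy, such as an ethoxy group, a chlorine atom or an amine. From the compounds shown here alone, the effect of removing the remaining methoxy group also remains open.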